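Swapping a carboxyazetidine for a hydroxypyrrolidine: cytotoxicity outlook

A few compounds are considered here, and "the series" means these few. Any claim that something is new, unique, unknown or untested is made for them only; others in the source may bear on it.

Measured compounds, with their values in an ADME assay on NCM460 cells (Homo sapiens) for cytotoxicity, read by CCK-8 assay, with a stated time of 48 h; a lower number here means a stronger inhibitor, a higher number a weaker inhibitor:
Compound 1 `COc1ccc(/C=C\c2cc(OC)c(OC)c(OC)c2)cc1OCc1ccc(CN2CC[C@H](C(=O)O)C2)cc1` gives > 50000 nM, a limit of the assay.
Compound 2 `COc1ccc(/C=C\c2cc(OC)c(OC)c(OC)c2)cc1OCc1ccc(CN2CC(C(=O)O)C2)cc1` gives > 50000 nM, a limit of the assay.
Compound 3 `COc1ccc(/C=C\c2cc(OC)c(OC)c(OC)c2)cc1OCc1ccc(CN2CCCCC2C(=O)O)cc1` gives > 50000 nM, a limit of the assay.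

Compound 2 therefore stands at no definite number: its result is only a limit, and the two other values shown are limits as well. The three compounds share one core and differ only in the ring attached to the saturated chain carbon bound to an aromatic carbon. Because (the limit of > 50000 nM in this assay, at which 3 of the 3 values shown sit), the steps a step that the two limits leave unreadable from compound 1 to compound 2, a step that the two limits leave unreadable from compound 1 to compound 3 and a step that the two limits leave unreadable from compound 2 to compound 3 cannot be read in size or direction.

Compound 4 `COc1ccc(/C=C\c2cc(OC)c(OC)c(OC)c2)cc1OCc1ccc(CN2CC[C@@H](O)C2)cc1` has not yet been measured. It differs from compound 2 as follows: 3-hydroxypyrrolidin-1-yl in place of 3-carboxyazetidin-1-yl on a saturated chain carbon bound to an aromatic carbon. For the measured compounds named here, no measured step matches this change, and the measured steps that would bear on it are all unreadable, so there is no basis for expecting either a rise or a fall beyond the scatter. The step of a number no higher from compound 2 to compound 4 (the limit leaves the size open) is therefore expected to stay within the usual scatter. Compound 4 is expected to give 50000 nM, with a range from 20000 nM to 150000 nM, most likely again reported only as a limit.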

Compound 4, half-maximal inhibitory concentration: 53000 nM
Compound 4: the middle estimate sits 1.1-fold (0.03 log units) below what was measured, and the stated range covers the measured number.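

None of the steps from compound 1, compound 2 or compound 3 to compound 4 can be read in size or direction, because those three results are limits and not numbers: the limit of > 50000 nM in this assay, at which 3 of the 4 values shown sit. The compounds shown leave open whether changing the ring on the saturated chain carbon bound to an aromatic carbon alters the result in this assay at all.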